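This account rests on a few compounds, and the source may have more. Where it says the series, first, only, none or still open, it means among the compounds named here.

Measured compounds:
compound 1 `CCCOCCn1c(N2CCCN(C)CC2)nc2ccccc21`, 16 nM
compound 2 `CCCOCCn1c(N2CCN(C)CC2)nc2ccccc21`, 20 nM
compound 3 `CCOCCn1c(N2CCN(CC)CC2)nc2ccccc21`, 18 nM

Of the compounds shown here, three share a core and have been tested in a functional assay on ileum for inhibition of histamine H1 receptor (Cavia porcellus); on this read-out lower numbers stand for stronger inhibition and higher numbers for weaker inhibition. Compound 1 gives 16 nM, compound 2 gives 20 nM and compound 3 gives 18 nM. Compound 2 holds the largest of the three numbers, but its gap to compound 3 and its gap to compound 1 both lie within the usual scatter of this assay, so the three cannot be told apart on these data.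

Compound 4 `CN1CCN(c2nc3ccccc3n2-c2ccccc2)CC1` has not yet been measured. It differs from compound 2 in one place: phenyl in place of 2-propoxyethyl on an aromatic nitrogen. Among the compounds with values here, no step between measured compounds shows what replacing the ether chain does, since every measured compound carries such a chain. The expected step of a 3.0-fold higher number from compound 2 to compound 4 (0.48 log units; beyond the scatter) is a modest weakening, larger than the scatter but uncertain in size. Compound 4 is therefore estimated at about 60 nM, within a range from 15 nM to 300 nM.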

Compound 4, half-maximal inhibitory concentration: 760 nM
Beside the measured number, compound 4's estimate is 13-fold (1.10 log units) below it, outside the stated range (above it).
By their numbers in this assay, from the lowest: compounds 1, 3 and 2 (each within the scatter of the next); then compound 4.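

In this assay, putting phenyl in place of 2-propoxyethyl on the aromatic nitrogen next to the ring atom that bears a 4-methylpiperazin-1-yl group gives a 38-fold higher number from compound 2 to compound 4 (1.58 log units; beyond the scatter), so inhibition at this position depends strongly on which group the nitrogen carries. The earlier compounds shown here could not show this, since each carries an ether chain on that nitrogen and their values lie within the scatter of one another. Both groups have 6 heavy atoms, so the step comes with no change in that count, and nothing available accounts for its size.

This single change does not separate the loss of the ether oxygen from the arrival of the aromatic ring. As far as these compounds go, whether a plain hexyl chain, or a benzyl group with its phenyl ring on a one-carbon link, would sit nearer compound 2 or compound 4 remains open.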